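Sulfonamide swap on the piperidine-bearing series

The compounds below may be only part of what the source reports. "The series", "measured", "known", "first", "only" and "open" are said of these compounds alone.

Measured so far:
compound 1, `COc1ccc(-c2cn3cc(C4=CCN(C(=O)c5ccc(Cl)cc5)CC4)ccc3n2)cc1OC`, 15300 nM
compound 2, `COc1ccc(-c2cn3cc(C4=CCN(S(=O)(=O)C5CCCC5)CC4)ccc3n2)cc1OC`, 7690 nM

Both numbers come from a functional assay on B16-F10 cells (Mus musculus) for antiproliferative activity, read by MTT assay, with a stated time of 48 h; a lower number here means a stronger inhibitor, a higher number a weaker inhibitor. Compound 2, with 7690 nM, has the lower of the two numbers, but the step of a 2.0-fold lower number from compound 1 to compound 2 (0.30 log units; within the scatter) lies within the scatter, so the two compounds are not separated in this assay.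

Compound 3, `COc1ccc(-c2cn3cc(C4=CCN(S(=O)(=O)c5ccccc5)CC4)ccc3n2)cc1OC`, has not yet been measured. It differs from compound 2 by phenyl in place of cyclopentyl on a sulfonyl sulfur. Among the measured compounds shown here, the only measured step, a 2.0-fold lower number from compound 1 to compound 2 (0.30 log units; within the scatter), exchanges the whole group on the ring nitrogen and does not isolate the ring on the sulfonyl sulfur; no measured pair shows cyclopentyl against phenyl on a sulfonamide. For the measured compounds named here, the one step available was within the scatter, and nothing suggests that a change of this kind should move the number beyond it.

Compound 3 is therefore expected to sit near compound 2, with the step of a 1.0-fold lower number from compound 2 to compound 3 (0.01 log units; within the scatter) expected to fall within the scatter. The estimate for compound 3 in this assay is 7500 nM, with a range from 2500 nM to 22000 nM.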

Compound 3, half-maximal inhibitory concentration: 13200 nM
For compound 3 the middle estimate is 1.8-fold (0.25 log units) below the measured one; the range from low to high includes it.
By their numbers in this assay, from the lowest: compounds 2, 3 and 1 (each within the scatter of the next).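

In this assay, among the compounds shown here, a 1.7-fold higher number from compound 2 to compound 3 (0.23 log units; within the scatter) is the first step that isolates the ring on a sulfonyl sulfur whose other neighbour is the sulfonamide nitrogen in a ring. It shows that a five-membered non-aromatic carbon ring and a six-membered aromatic one are not separated at this place. The step of a 1.2-fold lower number from compound 1 to compound 3 (0.06 log units; within the scatter) adds a second exchange of the whole group on the amine nitrogen in a ring, and with an aromatic ring on both sides, (4-chlorophenyl)carbonyl and phenylsulfonyl are not separated either. No data are available that could account for these steps.

All three groups on this nitrogen therefore remain unresolved in this assay, and the compounds shown do not establish that any change at this place can move the number beyond the scatter. As far as these compounds go, it remains open whether an amine or a carboxylic acid on the ring, or a longer alkyl chain in place of the ring on the sulfonyl sulfur, would separate from compound 2 and compound 3.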